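The source may hold more compounds than are shown below. What is called first, only, known or untested is meant among the compounds shown, and "the series" means these compounds.

In a functional assay on CHO cells for antagonist activity at adenosine receptor A2b (Homo sapiens) (on this read-out higher numbers stand for weaker inhibition and lower numbers for stronger inhibition), compound 1 `CCOC(=O)c1cnc(NC2CCCC2)n2nc(-c3ccco3)nc12` gives 4620 nM, and compound 2 `CCOC(=O)c1cnc(NCc2ccc(F)cc2)n2nc(-c3ccco3)nc12` gives 1970 nM. For compound 3 `CCOC(=O)c1cnc(NCCOC)n2nc(-c3ccco3)nc12` the assay reports only a limit, > 10000 nM. Compound 3 therefore stands at the weak end of the numbers shown, without a value of its own, one of the three results sitting at the limit of > 10000 nM in this assay, at which 1 of the 3 values shown sits. Compound 4 `CCOC(=O)c1cnc(N(C)C)n2nc(-c3ccco3)nc12` carries dimethylamino in place of (2-methoxyethyl)amino on an aromatic carbon. Going by the values given here, no measured pair makes this exact change. The two steps that lead into compound 3 both run the same way: an at least 2.1-fold higher number from compound 1 to compound 3 (0.33 log units; beyond the scatter) and an at least 5.0-fold higher number from compound 2 to compound 3 (0.70 log units; beyond the scatter), so exchanging cyclopentyl or 4-fluorobenzyl for the 2-methoxyethyl chain cost potency each time. Whether dropping the chain for dimethylamino recovers any of that cannot be read from these three compounds, so the expected step is set near zero, the estimated step that the limit leaves unreadable from compound 3 to compound 4, with a wide allowance. Compound 4 is estimated at 15000 nM, between 4000 nM and 60000 nM, and a limit rather than a number is again quite possible in this assay.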

Compound 4, inhibition constant: > 10000 nM
Compound 4 was reported as a limit; the forecaster's own chance of this, stated with the estimate: 60%; the middle value is on the limit's open side.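

In this assay compound 4 is reported only as a limit, > 10000 nM, and the step between compound 3 and compound 4 cannot be read, which leaves two results at the same limit: the limit of > 10000 nM in this assay, at which 2 of the 4 values shown sit.

At this carbon, para to an ethoxycarbonyl group, dimethylamino therefore gives no readable value, just as (2-methoxyethyl)amino does, and the change away from the two ring-bearing amino groups is an at least 2.1-fold higher number from compound 1 to compound 4 (0.33 log units; beyond the scatter) and an at least 5.0-fold higher number from compound 2 to compound 4 (0.70 log units; beyond the scatter). Among these four compounds, only those whose amino group carries a ring give a value rather than a limit.

From the compounds shown here alone, how far compound 3 and compound 4 lie beyond the limit remains open. So does whether an open chain can match cyclopentylamino, as a longer chain such as pentylamino would test, or whether a ring is needed, as cyclohexylamino or benzylamino would further probe.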